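Notes on aryl variation at the saturated ring carbon

The compounds below may be only part of what the source reports. "The series", "measured", "known", "first", "only" and "open" are said of these compounds alone.

Compound 3 `COc1cc(/C=C/C(=O)C2=C(/C=C/c3ccc(O)c(OC)c3)NC(=O)NC2c2cccc([N+](=O)[O-])c2)ccc1O` gives 51.2% in a functional assay, with a stated time of 20 min, tested at 10 uM (a higher number here means a stronger effect of the compound at the concentration tested, a lower number a weaker effect), the second highest of three numbers: compound 1 `COc1cc(/C=C/C(=O)C2=C(/C=C/c3ccc(O)c(OC)c3)NC(=O)NC2c2ccc(O)cc2)ccc1O` gives 75% and compound 2 `COc1cc(/C=C/C(=O)C2=C(/C=C/c3ccc(O)c(OC)c3)NC(=O)NC2c2ccc(N(C)C)cc2)ccc1O` gives 37.6%. Compound 4 `COc1cc(/C=C/C(=O)C2=C(/C=C/c3ccc(O)c(OC)c3)NC(=O)NC2c2ccccc2Cl)ccc1O` differs by 2-chlorophenyl in place of 3-nitrophenyl on a saturated ring carbon. Among the compounds with values here, the steps that bear on it all change the group on this saturated ring carbon: a number 23.8 percentage points lower from compound 1 to compound 3 (beyond the scatter), a number 13.6 percentage points higher from compound 2 to compound 3 (beyond the scatter), and a number 37.4 percentage points lower from compound 1 to compound 2 (beyond the scatter). None of them carries a 2-chlorophenyl, so the direction is open; such changes have moved this assay modestly to largely in either direction. Compound 4 is therefore expected to sit near compound 3, with a step of a number 3.2 percentage points lower from compound 3 to compound 4 (within the scatter) not confidently beyond the scatter. The estimate for compound 4 is 48%, between 28% and 68%.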

Compound 4, a percentage reported as activity, at one concentration (the size of the read-out at that concentration, not a potency): 40%
Compound 4: the middle estimate sits 8 percentage points above what was measured; the range from low to high includes it.
By their numbers in this assay, from the lowest: compounds 2 and 4 (each within the scatter of the next); then compound 3; then compound 1.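

In this assay the change to 2-chlorophenyl on this saturated ring carbon gives a number 11.2 percentage points lower from compound 3 to compound 4 (beyond the scatter) and a number 35 percentage points lower from compound 1 to compound 4 (beyond the scatter) as well, so 4-hydroxyphenyl stays ahead of a third replacement. 4-(Dimethylamino)phenyl and 2-chlorophenyl are not told apart, with a number 2.4 percentage points higher from compound 2 to compound 4 (within the scatter) as the step between them. Nothing at hand accounts for these differences. The compounds shown change the substituent and its place on the aryl ring together, so the two cannot be separated. From the compounds shown here alone, how a carboxylic acid or a saturated alkyl chain in place of the aryl group would read stays open.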